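The compounds below may be only part of what the source reports. "The series", "measured", "known", "first", "only" and "open" are said of these compounds alone.

Series notes, values from a functional assay on NCI-H460 cells (Homo sapiens) for inhibition, read by MTT assay, with a stated time of 24 h, tested at 1 ug/mL; on this read-out higher numbers stand for more inhibition of growth at the one concentration tested and lower numbers for less inhibition of growth:

- compound 1 `O=C(CCCCC(S)CCS)Nc1ccc(F)cc1`: 6.84%
- compound 2 `O=C(CCCCC(S)CCS)Nc1cccc(C(F)(F)F)c1`: 8.26%

Compound 1, at 6.84%, lies within the scatter of compound 2, at 8.26%, so the two cannot be ranked. Both values show little inhibition of growth in this assay.

The next compound to be read is compound 3 `O=C(CCCCC(S)CCS)Nc1ccc([N+](=O)[O-])cc1`. It keeps the core of compound 1 and carries nitro in place of fluoro on an aromatic carbon, para to a large group: nitro in place of fluoro on an aromatic carbon.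

Among the measured compounds shown here, no measured pair differs in one place only, so there is no direct step to carry over, and nothing measured so far shows what nitro does here. The expectation rests on the narrow spread of the two values alone, with compound 1 at 6.84% and compound 2 at 8.26%. No change beyond the scatter is expected, though a modest rise cannot be excluded.

The estimated a number 2.2 percentage points higher from compound 1 to compound 3 (within the scatter) is small.

For compound 3 the expected value in this assay is 9%, with an estimated range from 2% to 22%.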

Compound 3, percent growth inhibition at one concentration: 4.64%
Compound 3: the middle estimate sits 4.4 percentage points above what was measured, within the range that was stated.
By their numbers in this assay, from the lowest: compounds 3, 1 and 2 (each within the scatter of the next).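

In this assay, nitro in place of fluoro on an aromatic carbon, para to a large group, gives a number 2.2 percentage points lower from compound 1 to compound 3 (within the scatter). Among the compounds shown here, this is the first step that differs in one place only, and it shows that at this position, replacing one heavy atom with three heavy atoms and bringing in two hydrogen-bond acceptors does not move the read-out beyond the usual scatter, with inhibition of growth remaining small at the one concentration tested. No measurement in hand speaks to the reason for this result.

The compounds shown leave open whether any other group at this position, such as an amine or a carboxylic acid, would give a value beyond the scatter of compound 1, since the one step available covers only the exchange of fluoro for nitro. They also leave open whether changing the chain of the shared core, for example to a longer chain, would alter inhibition of growth in this assay, as all three compounds carry the same chain.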